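Cyclopropyl on the Amino Nitrogen of a Weak Scaffold

A few compounds are considered here, and "the series" means these few. Any claim that something is new, unique, unknown or untested is made for them only; others in the source may bear on it.

Compound 1 `CC(C)n1cnc2c(NC(=N)N)nc(N)nc21` gives 97200 nM in a functional assay on MCF7 cells (Homo sapiens) for inhibition, read by fluorescence, with a stated time of 72 h (a higher number here means a weaker inhibitor, a lower number a stronger inhibitor), the highest of the two numbers measured. Compound 2 `CC(C)Cn1cnc2c(NC(=N)N)nc(N)nc21` gives 96600 nM, and the step of a 1.0-fold lower number from compound 1 to compound 2 (0.00 log units; within the scatter) is flat. Compound 3 `N=C(N)Nc1nc(N)nc2c1ncn2CCN` reaches only a limit of this assay, > 100000 nM. The steps of an at least 1.0-fold higher number from compound 1 to compound 3 (0.01 log units; that floor lies within the scatter) and an at least 1.0-fold higher number from compound 2 to compound 3 (0.01 log units; that floor lies within the scatter) likewise show no movement, so every measured change across the series leaves the number unchanged. Among the measured compounds shown here, compound 4 `CC(C)n1cnc2c(NC(=N)N)nc(NC3CC3)nc21` differs from compound 1 by cyclopropyl in place of hydrogen on a nitrogen on an aromatic ring, a site that none of the measured steps touches. With nothing bearing on that position and all measured steps within the scatter, the expected step is a 1.0-fold lower number from compound 1 to compound 4 (0.01 log units; within the scatter), nothing beyond the scatter. Compound 4 is therefore estimated at 95000 nM, between 45000 nM and 200000 nM.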

Compound 4, half-maximal inhibitory concentration: 5400 nM
Beside the measured number, compound 4's estimate is 18-fold (1.25 log units) above it; measured number below the stated range.
By their numbers in this assay, from the lowest: compound 4; then compounds 2 and 1 (each within the scatter of the next). At a limit, above all of these: compound 3.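

The nitrogen on the aromatic ring proves to be a site where the number moves: an 18-fold lower number from compound 1 to compound 4 (1.26 log units; beyond the scatter). All earlier steps changed the group held by isopropyl in compound 1, and none went beyond the scatter. Compound 3 remains at a limit, not a number: the limit of > 100000 nM in this assay, at which 1 of the 4 values shown sits.

From the compounds shown here alone, whether a methyl, a cyclobutyl or a longer chain on this amino nitrogen would lower the number in this assay as cyclopropyl does remains open. So does whether cyclopropylamino would give a similar step with isobutyl or 2-aminoethyl in place of isopropyl.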